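A few compounds are considered here, and "the series" means these few. Any claim that something is new, unique, unknown or untested is made for them only; others in the source may bear on it.

Measured compounds:
compound 1 `CC(=O)c1c(NNc2ccc(Cl)cc2)cc(C)oc1=O` gives 57.3% in a functional assay on the whole organism for inhibition, with Rattus norvegicus as the target, read by paw edema, with a stated time of 2 h, at a dose of 50 mg/kg; on this read-out lower numbers stand for less inhibition and higher numbers for more inhibition at the one dose given (going by the name of the read-out)
compound 2 `CC(=O)c1c(NNc2cc(C)c3ccccc3n2)cc(C)oc1=O` gives 55.1% in this assay
compound 3 `Cc1ccc(-n2nc3cc(C)oc(=O)c3c2C)cc1` gives 58.4% in this assay

Compound 3 returns the largest of the three numbers, yet its gap to compound 1 and to compound 2 lies within the scatter of this assay, so the three cannot be ranked. Among the measured compounds shown here, no pair here differs in one place, so no measured step is available as a guide.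

Compound 4 `COc1ccc(-n2nc3cc(C)oc(=O)c3c2C)cc1` differs from compound 3 by methoxy in place of methyl on an aromatic carbon. For the measured compounds named here, with no single-change step to lean on, the change is expected to leave this assay essentially unmoved, neither direction favoured, and any shift likely inside the scatter.

Compound 4 is estimated at 57% in this assay, expected to fall between 45% and 69%, which would be a step of a number 1.4 percentage points lower from compound 3 to compound 4 (within the scatter).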

Compound 4, a percentage reported as inhibition, in the whole organism at one dose (the size of the read-out at that dose, not a potency): 53.9%
Compound 4: the middle estimate sits 3.1 percentage points above what was measured; the measured number falls inside the stated range.
By their numbers in this assay, from the lowest: compounds 4, 2, 1 and 3 (each within the scatter of the next).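

At this position, on an aromatic carbon para to a large group, the series now has its first single-change step: methoxy in place of methyl gives (a number 4.5 percentage points lower from compound 3 to compound 4 (within the scatter)) in this assay. The extra heavy atom and the hydrogen-bond acceptor that methoxy brings therefore leave the read-out within the scatter at the one dose given. No measurement at hand bears on the reason for this result.

On these data alone, whether an amine, a carboxylic acid or a longer chain on this same aromatic carbon would move the number beyond the scatter remains open. Also open, as far as these compounds go, is whether methoxy in place of methyl would give a similar step on the core of compound 1.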